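The source may hold more compounds than are shown below. What is called first, only, known or untested is meant among the compounds shown, and "the series" means these compounds.

Among the compounds with values here, in a functional assay on MDA-MB-231 cells (Homo sapiens) for inhibition, read by MTT assay, with a stated time of 72 h (a higher number here means a weaker inhibitor, a lower number a stronger inhibitor), compound 2 `CNC(=O)CCCCCCCn1nc(-c2ccc3oc(N)nc3c2)c2c(N)ncnc21` gives 2900 nM, the lower of the two numbers so far. Compound 1 `Nc1nc2cc(-c3nn(CCCCCC(=O)NO)c4ncnc(N)c34)ccc2o1` gives 19000 nM. Compound 3 `Nc1nc2cc(-c3nn(CCCCCCC(=O)NO)c4ncnc(N)c34)ccc2o1` differs from compound 2 by one change: hydroxycarbamoyl in place of (methylcarbamoyl)methyl on a saturated chain carbon, six bonds along the chain from an aromatic nitrogen. Hydroxycarbamoyl stands in place of (methylcarbamoyl)methyl on a saturated chain carbon, six bonds along the chain from an aromatic nitrogen. Within the data shown here, only one measured step bears on this: a 6.6-fold lower number from compound 1 to compound 2 (0.82 log units; beyond the scatter), which lies beyond the scatter and replaces hydroxycarbamoyl five bonds along the chain. Compound 3 carries the hydroxycarbamoyl of compound 1, but at the other chain place, so that step can only be read in reverse and with caution. A rise in this assay is therefore expected, smaller than the measured step. The estimated step is a 1.7-fold higher number from compound 2 to compound 3 (0.24 log units; within the scatter). For compound 3 the expected value is 5000 nM, within a range of 1200 nM to 20000 nM.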

Compound 3, half-maximal inhibitory concentration: 8430 nM
Compound 3: the middle estimate sits 1.7-fold (0.23 log units) below what was measured; measured number inside the range.
By their numbers in this assay, from the lowest: compound 2; then compound 3; then compound 1.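

In this assay, the hydroxycarbamoyl end group at this chain place still gives the higher number against (methylcarbamoyl)methyl (a 2.9-fold higher number from compound 2 to compound 3 (0.46 log units; beyond the scatter)), so the earlier gap between the two end groups is not confined to the shorter hydroxycarbamoyl chain of compound 1. Within the hydroxycarbamoyl pair, chain length alone also moves the number (a 2.3-fold lower number from compound 1 to compound 3 (0.35 log units; beyond the scatter)), with (hydroxycarbamoyl)methyl in place of hydroxycarbamoyl, an effect the earlier compounds could not separate from the change of end group. No evidence is at hand on the cause of either step.

The compounds shown leave open whether a still longer chain ending in hydroxycarbamoyl would lower the number further. They also leave open how a carboxylic acid or an amine at the chain end would compare with compound 2.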